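A few compounds are considered here, and "the series" means these few. Any claim that something is new, unique, unknown or untested is made for them only; others in the source may bear on it.

Compound 1 `Cc1cc(C(=O)NCN2CCC(c3cccc[n+]3[O-])CC2)ccc1F`: in a functional assay on HEK293 cells for agonist activity at D(4) dopamine receptor (Homo sapiens), read by FLIPR (a lower number here means that less compound is needed, a higher number that more compound is needed for the effect), compound 1 gives 50 nM.
Compound 2 `CC(C)Oc1cccc(NC(=O)CN2CCC(c3cccc[n+]3[O-])CC2)c1`: in this assay compound 2 gives 555 nM.

Of the two measured compounds, compound 2 stands at the higher number, and the gap between it and compound 1 is well beyond the usual scatter of repeated measurements, so compound 2 needs clearly more material for the same effect than compound 1 does. The two compounds share the piperidine bearing a pyridine N-oxide, but differ in the amide-containing side chain and in the aryl group, so nothing can be said about which single part is responsible.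

Compound 3 `O=C(CN1CCC(c2cccc[n+]2[O-])CC1)Nc1cccc(Cl)c1` is an untested relative of compound 2. The change is chloro in place of isopropoxy on an aromatic carbon. For the measured compounds named here, because compound 2 gives 555 nM and no closely related pair isolates this kind of exchange, the direction is uncertain; a small step toward a lower number is expected, within or only slightly beyond the scatter, written as a 1.6-fold lower number from compound 2 to compound 3 (0.20 log units; within the scatter). Compound 3 is therefore estimated at 350 nM, with a range from 120 nM to 1100 nM.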

Compound 3, half-maximal effective concentration: 62 nM
Compound 3: middle estimate off by 5.6-fold (0.75 log units), on the high side; the measured number lies below the stated range.
By their numbers in this assay, from the lowest: compounds 1 and 3 (each within the scatter of the next); then compound 2.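

For the compounds shown here, this is the first pair in the set that differs in one place only, so a single change can be read directly: chloro in place of isopropoxy on an aromatic carbon, meta to a large group, gives a 9.0-fold lower number from compound 2 to compound 3 (0.95 log units; beyond the scatter) in this assay. With the rest of the molecule unchanged, this one exchange, in which four heavy atoms leave and one enters, moves the number beyond the usual scatter, so the substituent at this position clearly matters for the read-out. Nothing measured here shows what about the exchange produces the step.

A single pair cannot separate the gain from adding chloro from the gain from removing isopropoxy, and it leaves open whether a smaller ether such as methoxy, or a fluoro or trifluoromethyl group on the same carbon, would behave more like chloro or more like isopropoxy. Going by these compounds alone, it is also open whether the same exchange would give a step of similar size on a different side chain, such as the one in compound 1.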